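Exchanging One Fluorinated Group in an Antiproliferative Series

This account rests on a few compounds, and the source may have more. Where it says the series, first, only, none or still open, it means among the compounds named here.

Compound 1 `CC(O)(CSc1ccc(F)cc1)C(=O)Nc1ccc(S(F)(F)(F)(F)F)cc1`: 25400 nM
Compound 2 `CC(O)(COc1cccc(S(F)(F)(F)(F)F)c1)C(=O)Nc1cccc(S(F)(F)(F)(F)F)c1`: 30700 nM

In a functional assay on DU-145 cells (Homo sapiens) for antiproliferative activity, read by propidium iodide staining, with a stated time of 96 h (on this read-out higher numbers stand for weaker inhibition and lower numbers for stronger inhibition), compound 2 gives 30700 nM, which lies within the usual scatter of compound 1 at 25400 nM. Compound 3 `CC(O)(COc1cccc(OC(F)(F)F)c1)C(=O)Nc1cccc(S(F)(F)(F)(F)F)c1` differs from compound 2 in one place: a group of 5 heavy atoms (1 carbon, 1 oxygen, 3 fluorine; no ring) in place of a group of 6 heavy atoms (5 fluorine, 1 sulfur; no ring), on an aromatic carbon. Trifluoromethoxy enters on an aromatic carbon, meta to a large group. Going by the values given here, no measured pair shows this exchange, so the data offer no direction for it. The expected step, a 1.2-fold lower number from compound 2 to compound 3 (0.07 log units; within the scatter), stays within the scatter. For compound 3 the estimated value is 26000 nM, with an expected range from 11000 nM to 60000 nM.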

Compound 3, half-maximal inhibitory concentration: 30100 nM
Beside the measured number, compound 3's estimate is 1.2-fold (0.06 log units) below it, and the stated range covers the measured number.
By their numbers in this assay, from the lowest: compounds 1, 3 and 2 (each within the scatter of the next).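

Exchanging the group of 6 heavy atoms (5 fluorine, 1 sulfur) for trifluoromethoxy on this aromatic carbon gives a 1.0-fold lower number from compound 2 to compound 3 (0.01 log units; within the scatter) in this assay. This first direct comparison at the position shows that the two fluorinated groups cannot be told apart in this read-out. No measurement at hand accounts for this result. Still open, going by these compounds, is whether a group without fluorine on this carbon, such as a methyl group, an amine or a carboxylic acid, would read the same. Also open, on these data alone, is whether the same exchange elsewhere on the shared core would do so.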